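Removing the fluorine at the quaternary acid carbon

The source may report more compounds than this note shows. Statements on the series, on what has been measured and on what is new or still open speak of the compounds shown alone.

Compound 3 `COc1ccc(F)c([C@H]2CC[C@H](COc3cccc([C@H](C4CC4)[C@@](C)(F)C(=O)O)c3)CC2)c1` carries a 1-carboxy-1-fluoroethyl group. In a functional assay on HEK293 cells for agonist activity at Free fatty acid receptor 1 (Homo sapiens), read by FLIPR and calcium flux (on this read-out lower numbers stand for an effect already at smaller amounts and higher numbers for an effect only at larger amounts of compound), compound 3 gives 0.25 nM, the second highest of the three numbers recorded; compound 1 `COc1ccc(F)c([C@H]2CC[C@H](COc3cccc([C@H](C4CC4)[C@H](C)C(=O)O)c3)CC2)c1` gives 0.2 nM and compound 2 `COc1ccc(F)c([C@H]2CC[C@H](COc3cccc([C@H](C4CC4)[C@@H](F)C(=O)O)c3)CC2)c1` gives 1.1 nM. The unmeasured compound 4 `COc1ccc(F)c([C@H]2CC[C@H](COc3cccc([C@H](C4CC4)C(C)(C)C(=O)O)c3)CC2)c1` differs from compound 3 by 1-carboxy-1-methylethyl in place of 1-carboxy-1-fluoroethyl on a saturated chain carbon bound to an aromatic carbon and a saturated ring carbon. Two recorded steps speak to this exchange of fluorine for methyl: a 5.5-fold higher number from compound 1 to compound 2 (0.74 log units; beyond the scatter) shows that fluorine in place of methyl weakened the effect, while a 4.4-fold lower number from compound 2 to compound 3 (0.64 log units; beyond the scatter) shows that adding a methyl to the fluorine-bearing carbon recovered it; a 1.3-fold higher number from compound 1 to compound 3 (0.10 log units; within the scatter) shows that adding fluorine to the methyl-bearing carbon changed little. Methyl has therefore never fallen behind fluorine in this series, so compound 4 is expected to sit close to compound 3, with a 1.4-fold higher number from compound 3 to compound 4 (0.15 log units; within the scatter) as the expected step. Compound 4 is estimated at 0.35 nM, with a range from 0.1 nM to 1.5 nM.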

Compound 4, half-maximal effective concentration: 0.11 nM
For compound 4 the middle estimate is 3.2-fold (0.50 log units) above the measured one, within the range that was stated.
By their numbers in this assay, from the lowest: compounds 4, 1 and 3 (each within the scatter of the next, the first and the last beyond it); then compound 2.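

In this assay, methyl in place of the fluorine of compound 3 gives a 2.3-fold lower number from compound 3 to compound 4 (0.36 log units; beyond the scatter), so the 1-carboxy-1-methylethyl group separates from the 1-carboxy-1-fluoroethyl group beyond the scatter, although fluorine added to compound 1 had produced no such separation. The widest step in the set, a 10-fold lower number from compound 2 to compound 4 (1.00 log units; beyond the scatter), shows how far the carboxy(fluoro)methyl group stands from the 1-carboxy-1-methylethyl group, while a 1.8-fold lower number from compound 1 to compound 4 (0.26 log units; within the scatter) leaves compound 4 indistinguishable from compound 1, so the second methyl brings no readable gain over the 1-carboxyethyl group. No supporting data are available to explain these differences.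

As far as these compounds go, what a 1-carboxy-1-methylpropyl or a 1-carboxy-1-hydroxyethyl group would give at this place remains open. From the compounds shown here alone, it is also open whether the order seen in this assay would hold with a different group in place of the cyclopropyl ring.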